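This account rests on a few compounds, and the source may have more. Where it says the series, first, only, none or still open, it means among the compounds named here.

Compound 1 `Cc1ccc(CCOc2ccc(-c3c(C)nc(C)c([C@H](OC(C)(C)C)C(=O)O)c3N3CCC(C)(C)CC3)cc2)s1`: in an ADME assay on microsomes from liver (Homo sapiens) for metabolic stability, read by LC-MS, tested at 0.5 uM (a lower number here means that the compound disappears faster, a higher number that the compound lasts longer), compound 1 gives > 2 h, which is a limit of the assay and not a number.
Compound 2 `Cc1ncsc1CCOc1ccc(-c2c(C)nc(C)c([C@H](OC(C)(C)C)C(=O)O)c2N2CCC(C)(C)CC2)cc1`: in this assay compound 2 gives 1.5 h.

In this assay compound 2 holds the only number shown; the further value, that of compound 1, is a limit of the assay. That limit is the limit of > 2 h in this assay, at which 1 of the 2 values shown sits. For the measured compounds named here, the single measured step, an at least 1.3-fold lower number from compound 1 to compound 2 (0.12 log units; that floor lies within the scatter), has a floor that lies within the scatter, so it points in no firm direction. Compound 3 `Cc1nc(C)c(CCOc2ccc(-c3c(C)nc(C)c([C@H](OC(C)(C)C)C(=O)O)c3N3CCC(C)(C)CC3)cc2)s1` differs from compound 2 by methyl in place of hydrogen on an aromatic carbon. The measured step concerns a different kind of change, the swap of one aromatic ring for another, rather than the addition of a methyl group to a ring that is already present, so it bears only loosely on this step. No measured step shows a shift beyond the scatter, and a change this small gives no reason to expect one. The expectation for compound 3 is therefore a step of no change at the digits printed from compound 2 to compound 3 (within the scatter), none beyond the scatter. Compound 3 is estimated to give 1.5 h in this assay, within 0.8 h to 2.5 h.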

Compound 3, half-life: 0.917 h
The estimate for compound 3 lay 1.6-fold (0.21 log units) above the measured number; the range from low to high includes it.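

In this assay, placing a methyl group on the aromatic carbon next to the ring nitrogen and the ring sulfur gives a 1.6-fold lower number from compound 2 to compound 3 (0.21 log units; within the scatter), so this one added carbon does not by itself clearly separate the two compounds. For the compounds shown here, the comparison with the other ring type reads differently: 2,4-dimethyl-1,3-thiazol-5-yl in place of 5-methylthiophen-2-yl gives an at least 2.1-fold lower number from compound 1 to compound 3 (0.33 log units; beyond the scatter), the first step in this short series to pass beyond the scatter, whereas the floor of an at least 1.3-fold lower number from compound 1 to compound 2 (0.12 log units; that floor lies within the scatter) stayed within it. Compound 1 carries a limit of the assay and not a number, so this step has a floor but no known size: the limit of > 2 h in this assay, at which 1 of the 3 values shown sits.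

As far as these compounds go, whether a different group on this same ring carbon, such as chlorine, methoxy or trifluoromethyl, would track with the methyl group remains open, as does the real size of the step from the 5-methylthiophen-2-yl ring. The compounds shown also do not reveal which part of each molecule is consumed in the microsomes, so the site of breakdown is still unknown.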